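From 4-fluorophenyl to pyridin-3-yl on a shared core

The compounds below may be only part of what the source reports. "The series", "measured", "known", "first", "only" and "open" are said of these compounds alone.

In a physicochemical assay for solubility, read by LC-MS, in phosphate buffer, measured as thermodynamic solubility, with a stated time of 24 h, at pH 7.4 (on this read-out higher numbers stand for higher solubility and lower numbers for lower solubility), compound 1 `Cn1cc(-c2cnc3[nH]cc(-c4ccc(F)cc4)c3c2)cn1` gives 9000 nM. Compound 2 `Cn1cc(-c2cnc3[nH]cc(-c4ccc(F)c(F)c4)c3c2)cn1` gives 5000 nM, which is within the scatter of compound 1, while compound 3 `Cn1cc(-c2cnc3[nH]cc(-c4ccc(C(=O)O)cc4)c3c2)cn1` gives 850000 nM. Compound 1 therefore sits far under compound 3 and cannot be told apart from compound 2.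

Compound 4 `Cn1cc(-c2cnc3[nH]cc(-c4cccnc4)c3c2)cn1` has not been measured yet. It carries pyridin-3-yl in place of 4-fluorophenyl on an aromatic carbon.

Two measured steps offer some guidance. Fluoro in place of hydrogen gives a 1.8-fold lower number from compound 1 to compound 2 (0.26 log units; within the scatter), and carboxy in place of fluoro gives a 94-fold higher number from compound 1 to compound 3 (1.98 log units; beyond the scatter). Neither step replaces a whole ring, so both are only rough guides. Compound 4 has no carboxy, so a step on the scale of the larger one is not expected. A moderate upward step in this assay is expected instead, and the estimated change is a 4.4-fold higher number from compound 1 to compound 4 (0.65 log units; beyond the scatter).

For compound 4 the estimated value is 40000 nM, with an expected range of 10000 nM to 150000 nM.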

Compound 4, solubility: 97000 nM
For compound 4 the middle estimate is 2.4-fold (0.38 log units) below the measured one, and the stated range covers the measured number.
By their numbers in this assay, from the lowest: compounds 2 and 1 (each within the scatter of the next); then compound 4; then compound 3.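

In this assay, replacing the whole ring on this aromatic carbon of the five-membered ring gives an 11-fold higher number from compound 1 to compound 4 (1.03 log units; beyond the scatter), a large step. The earlier compounds shown here showed a large rise at this position only with carboxy on the phenyl ring, whereas this step shows that a large rise does not require carboxy: pyridin-3-yl, which carries no net charge, also gives one. The change removes the fluoro and puts a nitrogen into the ring at the same time, and nothing measured here gives a reason for the rise.

On these data alone, it remains open how the step divides between losing the fluoro and gaining the ring nitrogen, a question that a plain phenyl at this position could help settle. As far as these compounds go, it is also open whether a pyridin-4-yl ring, or a pyridin-3-yl ring bearing an amine, would give a similar number.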